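Carboxymethyl in place of isopropyl on an aromatic nitrogen

A few compounds are considered here, and "the series" means these few. Any claim that something is new, unique, unknown or untested is made for them only; others in the source may bear on it.

In a functional assay (Homo sapiens) for inhibition, with a stated time of 72 h (a lower number here means a stronger inhibitor, a higher number a weaker inhibitor), compound 1 `COc1cc(C(=O)c2ccc3[nH]ccc3c2)cc(OC)c1OC` gives 111 nM with a hydrogen on the aromatic nitrogen. Compound 2 `COc1cc(C(=O)c2ccc3c(ccn3C(C)C)c2)cc(OC)c1OC` carries isopropyl there and gives 1600 nM, the higher of the two numbers, which makes it the weaker inhibitor of the pair. Compound 3 `COc1cc(C(=O)c2ccc3c(ccn3CC(=O)O)c2)cc(OC)c1OC` keeps the shared core but has carboxymethyl in place of isopropyl on that nitrogen: carboxymethyl in place of isopropyl on an aromatic nitrogen. Among the compounds with values here, only one measured step bears on this position, a 14-fold higher number from compound 1 to compound 2 (1.16 log units; beyond the scatter), a large rise on replacing hydrogen with isopropyl. Within the data shown here, that single step shows that the number can move strongly with what this nitrogen carries, but no measured compound has carboxymethyl there, so the evidence is thin. A return towards compound 1 at 111 nM seems unlikely, since the only substituent tested so far raised the number. A modest further rise in this assay is therefore expected, with wide uncertainty. The expected step is a 2.2-fold higher number from compound 2 to compound 3 (0.34 log units; beyond the scatter). For compound 3 the estimated value is 3500 nM, with an expected range from 700 nM to 20000 nM.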

Compound 3, half-maximal inhibitory concentration: 476 nM
Beside the measured number, compound 3's estimate is 7.4-fold (0.87 log units) above it, outside the stated range (below it).
By their numbers in this assay, from the lowest: compound 1; then compound 3; then compound 2.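

In this assay this nitrogen does not simply punish every substituent, as the first pair alone might have suggested: with carboxymethyl in place of isopropyl there is a 3.4-fold lower number from compound 2 to compound 3 (0.53 log units; beyond the scatter) and so part of the rise seen with isopropyl is recovered. Hydrogen still gives the lowest number of the three, since putting carboxymethyl in its place leads to a 4.3-fold higher number from compound 1 to compound 3 (0.63 log units; beyond the scatter) and neither substituent shown reaches the level of compound 1. The position therefore tells these two groups apart, although no supporting measurement is available to say what lies behind the difference.

The compounds shown leave open whether the carbonyl and hydroxyl of the carboxymethyl group are needed for this partial recovery, or whether a small group such as methyl, or the methyl ester of the same chain, would give a similar number. As far as these compounds go, it also remains open how an amine on a short chain, or a longer chain ending in a carboxylic acid, would compare with compound 1 at this nitrogen.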